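A Charged Four-Membered Ring in Place of a Branched Chain

The source may report more compounds than this note shows. Statements on the series, on what has been measured and on what is new or still open speak of the compounds shown alone.

Measured compounds:
compound 1, `CCN1CCc2c(sc(NC(=O)Nc3ccc4ccccc4c3)c2C(N)=O)C1`: 1780 nM
compound 2, `CC(C)(C)OC(=O)CCC[N+]1(C)CCc2c(sc(NC(=O)Nc3ccc(Cl)cc3)c2C(N)=O)C1`: 250 nM
compound 3, `CCC(C)(C)C1CCc2c(sc(NC(=O)Nc3ccc(Cl)cc3)c2C(N)=O)C1`: > 25000 nM

All three were tested in a functional assay (strain AB) with Danio rerio as the target, read by microscopy, with a stated time of 1 h; on this read-out lower numbers stand for an effect already at smaller amounts and higher numbers for an effect only at larger amounts of compound. Compound 1 gives 1780 nM and compound 2 gives 250 nM. For compound 3 only a limit is recorded, (the limit of > 25000 nM in this assay, at which 1 of the 3 values shown sits), so compound 3 stands without a number at the edge of what this assay reports.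

Compound 4, `C[N+]1(C2CCc3c(sc(NC(=O)Nc4ccc(Cl)cc4)c3C(N)=O)C2)CCC1`, differs from compound 3 in one place: a group of 5 heavy atoms (4 carbon, 1 nitrogen; one four-membered non-aromatic ring with 1 hetero atom) in place of a group of 5 heavy atoms (5 carbon; no ring), on a saturated ring carbon.

Compound 2 also carries a nitrogen with a net charge, and in this assay compound 2 gives 250 nM. Compound 3, whose group at that place carries no charge, shows only the limit. Within the data shown here, no measured pair isolates this change, so the size of the step is an expectation: the step of an at least 16-fold lower number from compound 3 to compound 4 (1.22 log units; beyond the scatter) is expected to run toward an effect at smaller amounts, well beyond the usual scatter. For compound 4 the estimated value in this assay is 1500 nM, with a range from 300 nM to 10000 nM.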

Compound 4, half-maximal effective concentration: 3920 nM
Compound 4: the middle estimate sits 2.6-fold (0.42 log units) below what was measured; the measured number falls inside the stated range.
By their numbers in this assay, from the lowest: compound 2; then compound 1; then compound 4. At a limit, above all of these: compound 3.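

At the saturated ring carbon, putting the charged four-membered ring in place of the uncharged 1,1-dimethylpropyl group, with the heavy-atom count unchanged, gives the first view of what one change at one place does: in this assay it gives an at least 6.3-fold lower number from compound 3 to compound 4 (0.80 log units; beyond the scatter). Among these compounds, compound 3 carries a limit and not a number, so this step is only a lower bound: the limit of > 25000 nM in this assay, at which 1 of the 4 values shown sits. The earlier compounds differ from one another in more than one place, so none of them could show this.

The compounds shown do not separate the charge from the ring, and a cyclobutyl group or an uncharged dimethylamino group at that carbon would help tell the two apart. Going by these compounds, how a carboxylic acid or a longer chain at the same place would read also stays open.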